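Methyl on the Acid Chain: Expected Half-Life of Compound 4

The source may report more compounds than this note shows. Statements on the series, on what has been measured and on what is new or still open speak of the compounds shown alone.

Three measured compounds share one core and differ only in the acid-bearing chain. In an ADME assay on the whole organism (strain CD-1) for metabolic stability, with Mus musculus as the target, at a dose of 3 mg/kg by the intravenous route (on this read-out lower numbers stand for a shorter-lived compound and higher numbers for a longer-lived compound), compound 1 `CN(Cc1ccccc1OCCCCCC(=O)O)C(=O)c1ccc(-c2ccco2)cc1` gives 1.7 h, the second highest of the three numbers. Compound 2 `CN(Cc1ccccc1OCCC[C@@H]1C[C@H]1C(=O)O)C(=O)c1ccc(-c2ccco2)cc1` gives 3.5 h, and the step of a 2.1-fold higher number from compound 1 to compound 2 (0.31 log units; beyond the scatter) lies beyond the scatter. Compound 3 `C/C(=C\CCCOc1ccccc1CN(C)C(=O)c1ccc(-c2ccco2)cc1)C(=O)O` gives 1.2 h, and the step of a 1.4-fold lower number from compound 1 to compound 3 (0.15 log units; within the scatter) stays within it. Compound 4 `CC(CCOc1ccccc1CN(C)C(=O)c1ccc(-c2ccco2)cc1)CCC(=O)O` is still unmeasured; it differs from compound 1 by methyl in place of hydrogen on a saturated chain carbon bound to two saturated chain carbons. Going by the values given here, no measured step makes exactly this change. The nearest is a 1.4-fold lower number from compound 1 to compound 3 (0.15 log units; within the scatter), which also brings in a methyl, though as part of the 2-carboxyprop-1-en-1-yl group, and it stayed within the scatter. Compound 4 is therefore expected to give 1.9 h (range 1 h to 3.5 h), an expected step of a 1.1-fold higher number from compound 1 to compound 4 (0.05 log units; within the scatter) that does not pass the scatter.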

Compound 4, half-life: 1.7 h
Beside the measured number, compound 4's estimate is 1.1-fold (0.05 log units) above it, within the range that was stated.
By their numbers in this assay, from the lowest: compounds 3, 1 and 4 (each within the scatter of the next); then compound 2.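

In this assay, methyl in place of hydrogen on a saturated chain carbon bound to two saturated chain carbons gives no change at the digits printed from compound 1 to compound 4 (within the scatter) at this position, so this change leaves the half-life where it was. Compound 4 also cannot be told apart from the unsaturated chain, with a 1.4-fold higher number from compound 3 to compound 4 (0.15 log units; within the scatter) on that comparison, whereas the cyclopropyl-bearing chain stays separate, with a 2.1-fold lower number from compound 2 to compound 4 (0.31 log units; beyond the scatter) beyond the scatter. No evidence is available to explain these results.

Left open is whether an ethyl or a hydroxyl group on this same carbon would shift the half-life. A longer chain carrying the carboxylic acid also remains untested among these compounds.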